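Urea series: fluoro for trifluoromethyl on the benzyl ring

This account rests on a few compounds, and the source may have more. Where it says the series, first, only, none or still open, it means among the compounds named here.

Of the compounds shown here, two of the shared core have been measured in a functional assay on HT-29 cells (Homo sapiens) for inhibition, read by MTT assay, with a stated time of 48 h; on this read-out lower numbers stand for stronger inhibition and higher numbers for weaker inhibition. Compound 1 `Cc1ccc(NC(=S)NC(=O)c2ccc(OCc3ccc(F)cc3)cc2)cc1-c1nc2ccccc2[nH]1` gives 1910 nM. Compound 2 `Cc1ccc(NC(=O)NC(=O)c2ccc(OCc3ccc(C(F)(F)F)cc3)cc2)cc1-c1nc2ccccc2[nH]1` gives 7830 nM, the highest of the two numbers, with compound 1 as its nearest neighbour on a difference beyond the scatter. For the measured compounds named here, no pair of measured compounds differs in one place only, so no measured step is available.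

Compound 3 `Cc1ccc(NC(=O)NC(=O)c2ccc(OCc3ccc(F)cc3)cc2)cc1-c1nc2ccccc2[nH]1` awaits measurement in this assay. It differs from compound 2 as fluoro in place of trifluoromethyl on an aromatic carbon; the group sits on an aromatic carbon of a six-membered aromatic ring of carbon only.

Going by the values given here, with no measured step of this kind to rest on, a modest step toward a lower number is expected, one that may or may not clear the scatter: a 2.0-fold lower number from compound 2 to compound 3 (0.29 log units; within the scatter). Compound 3 is expected to give 4000 nM, with a range from 1500 nM to 12000 nM.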

Compound 3, half-maximal inhibitory concentration: 980 nM
Compound 3: middle estimate off by 4.1-fold (0.61 log units), on the high side, and the stated range ends above it.
By their numbers in this assay, from the lowest: compounds 3 and 1 (each within the scatter of the next); then compound 2.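

Within the urea series, going from 4-(trifluoromethyl)benzyl to 4-fluorobenzyl gives an 8.0-fold lower number from compound 2 to compound 3 (0.90 log units; beyond the scatter), the first measured step at this position, and it shows that the number in this assay depends on the group held here. The 4-fluorobenzyl thiourea compound 1 gives 1910 nM and its urea counterpart compound 3 gives 980 nM, values within the scatter of each other, so this pair shows no separation between the two linkers. The data hold no measurement that could explain the size of the step.

Whether the same change has a similar effect in the thiourea series remains open, as only the 4-fluorobenzyl member is shown there. Also open, from the compounds shown here alone, is how a chloro, methoxy or amine group would read at this position.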